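This account rests on a few compounds, and the source may have more. Where it says the series, first, only, none or still open, it means among the compounds named here.

Measured so far in a functional assay on HepG2 cells (Homo sapiens) for cytotoxicity, read by MTT assay, with a stated time of 48 h; a lower number here means a stronger inhibitor, a higher number a weaker inhibitor:
compound 1 `O=C(CSc1nnc(-c2ccncc2)o1)N/N=C/c1ccccc1` gives 17300 nM;
compound 2 `O=C(CSc1nnc(-c2ccncc2)o1)N/N=C/c1ccc(Cl)cc1` gives 15700 nM;
compound 3 `O=C(CSc1nnc(-c2ccncc2)o1)N/N=C/c1ccc(Br)cc1` gives 18600 nM.

Compound 1 holds the second highest of these three numbers, but all three lie within the scatter of one another: the step of a 1.1-fold lower number from compound 1 to compound 2 (0.04 log units; within the scatter) and the step of a 1.1-fold higher number from compound 1 to compound 3 (0.03 log units; within the scatter) are within the scatter, as is a 1.2-fold higher number from compound 2 to compound 3 (0.07 log units; within the scatter). Compound 4 `O=C(CSc1nnc(-c2ccncc2)o1)N/N=C/c1cc(Br)cc(Br)c1O` differs from compound 1 by 3,5-dibromo-2-hydroxyphenyl in place of phenyl on a carbon with a double bond to nitrogen. Among the measured compounds shown here, no measured compound carries a hydroxyl on that ring, so the only comparable steps are the chloro and bromo additions above, neither of which moved the number beyond the scatter. Because a 1.1-fold higher number from compound 1 to compound 3 (0.03 log units; within the scatter) shows bromo alone changing little, a step of a 1.4-fold lower number from compound 1 to compound 4 (0.16 log units; within the scatter) is expected, at most a modest drop. Compound 4 is estimated at 12000 nM, with a range from 5000 nM to 30000 nM.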

Compound 4, half-maximal inhibitory concentration: 6540 nM
For compound 4 the middle estimate is 1.8-fold (0.26 log units) above the measured one; the range from low to high includes it.
By their numbers in this assay, from the lowest: compound 4; then compounds 2, 1 and 3 (each within the scatter of the next).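

In this assay, the place on a carbon with a double bond to nitrogen now shows a change beyond the scatter: 3,5-dibromo-2-hydroxyphenyl gives a 2.6-fold lower number from compound 1 to compound 4 (0.42 log units; beyond the scatter), and the single-halogen compounds give the same picture, with a 2.4-fold lower number from compound 2 to compound 4 (0.38 log units; beyond the scatter) and a 2.8-fold lower number from compound 3 to compound 4 (0.45 log units; beyond the scatter). The number can therefore move with this ring, although the chloro of compound 2 and the bromo of compound 3 left it within the scatter of compound 1. No measurement here explains this drop.

The hydroxyl and both bromo groups enter together, leaving their separate shares unresolved. On these data alone, whether an amine in place of the hydroxyl would give a similar number also stays open.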